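Working notes on ring-substituted aminopurine amides at the receptor

The source may report more compounds than this note shows. Statements on the series, on what has been measured and on what is new or still open speak of the compounds shown alone.

Measured so far:
compound 1 `CNC(=O)C1CC=CC1n1cnc2c(N)ncnc21`: 22%
compound 2 `CNC(=O)C1CC=CC1n1cnc2c(NC3CCCC3)ncnc21`: < 10%

In an assay on cell membranes for displacement of a labelled ligand from adenosine receptor A1 (Rattus norvegicus), tested at 100 uM (a higher number here means more inhibition at the concentration tested (going by the name of the read-out), a lower number less inhibition), compound 1 gives 22%. Compound 2 reports only a limit of the assay, < 10%; this is not a number but the boundary of the read-out. Compound 2 thus sits at the limit of < 10% in this assay, at which 1 of the 2 values shown sits. Within the data shown here, the one measured step, a number at least 12 percentage points lower from compound 1 to compound 2 (beyond the scatter), accompanies cyclopentyl in place of hydrogen on a nitrogen on an aromatic ring and lowers inhibition.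

Compound 3 `CNC(=O)C1CC=CC1n1cnc2c(NCc3ccccc3)ncnc21` carries the change (benzyl in place of cyclopentyl on a nitrogen on an aromatic ring). Among the measured compounds shown here, no measured step covers benzyl at this position; the only step available shows that a substituent on this nitrogen reduced inhibition to the limit. Compound 3 is therefore expected to remain near that limit, with a step that the limit leaves unreadable from compound 2 to compound 3 expected to be small or none beyond the scatter. For compound 3 the estimate in this assay is 9%, with a range from 0% to 25%.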

Compound 3, a percentage reported as inhibition, at one concentration (the size of the read-out at that concentration, not a potency): < 10%
Compound 3 was reported as a limit; the forecaster's own chance of this, stated with the estimate: 55%; the middle value lies beyond the limit too.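

In this assay compound 3 gives < 10%, a limit of the assay and not a number. Benzyl in place of hydrogen on this nitrogen goes with a number at least 12 percentage points lower from compound 1 to compound 3 (beyond the scatter), so the drop now appears with both a non-aromatic ring in compound 2 and an aromatic ring in compound 3, not with cyclopentyl alone. The step between these two substituted compounds cannot be read, and the series now gathers at the floor of the read-out: the limit of < 10% in this assay, at which 2 of the 3 values shown sit.

Going by these compounds, how cyclopentyl and benzyl rank against each other stays open, as does the question of whether any substituent on this nitrogen keeps inhibition readable. A small methyl group, or a longer chain ending in an amine or a carboxylic acid, would test that question.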